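Changing the aryl group on the sulfonyl sulfur

The source may report more compounds than this note shows. Statements on the series, on what has been measured and on what is new or still open speak of the compounds shown alone.

Measured so far in an assay on HEK293 cells for displacement of a labelled ligand from 5-hydroxytryptamine receptor 6 (Homo sapiens), with a stated time of 60 min, tested at 1 uM, in the presence of a further agent that is not named here; on this read-out higher numbers stand for a stronger effect at the one concentration tested and lower numbers for a weaker effect:
compound 1 `COc1cc(N)c(Cl)cc1C(=O)CCC1CCN(CCNS(=O)(=O)c2ccc(N)cc2)CC1`: 46%
compound 2 `COc1cc(N)c(Cl)cc1C(=O)CCC1CCN(CCNS(=O)(=O)c2cc(Br)ccc2Br)CC1`: 52%
compound 3 `COc1cc(N)c(Cl)cc1C(=O)CCC1CCN(CCNS(=O)(=O)c2ccc3c(c2)NC(=O)CO3)CC1`: 40%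

Compound 3 holds the lowest of the three numbers, yet a number 6 percentage points lower from compound 1 to compound 3 (within the scatter), while only a number 12 percentage points lower from compound 2 to compound 3 (beyond the scatter). Compound 4 `COc1ccc(S(=O)(=O)NCCN2CCC(CCC(=O)c3cc(Cl)c(N)cc3OC)CC2)cc1OC` differs from compound 3 in one place: a group of 10 heavy atoms (8 carbon, 2 oxygen; one six-membered aromatic ring of carbon only) in place of a group of 11 heavy atoms (8 carbon, 1 nitrogen, 2 oxygen; one six-membered non-aromatic ring with 2 hetero atoms, one six-membered aromatic ring of carbon only), on a sulfonyl sulfur. All three measured steps change the same group on the sulfonyl sulfur, and they stayed small: a number 6 percentage points higher from compound 1 to compound 2 (within the scatter) and a number 6 percentage points lower from compound 1 to compound 3 (within the scatter), with a number 12 percentage points lower from compound 2 to compound 3 (beyond the scatter) the only one beyond the scatter. A step of similar size is therefore expected here, in either direction or none, so compound 4 is estimated at 46% in this assay, between 30% and 62%, which would mean an expected a number 6 percentage points higher from compound 3 to compound 4 (within the scatter).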

Compound 4, a percentage reported as inhibition, at one concentration (the size of the read-out at that concentration, not a potency): 58%
Compound 4: middle estimate off by 12 percentage points, on the low side, within the range that was stated.
By their numbers in this assay, from the lowest: compounds 3, 1, 2 and 4 (each within the scatter of the next, the first and the last beyond it).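

In this assay, among these compounds, the largest step at this place so far is a number 18 percentage points higher from compound 3 to compound 4 (beyond the scatter) and 3,4-dimethoxyphenyl also gives a number 12 percentage points higher from compound 1 to compound 4 (beyond the scatter) so the aryl group on the sulfonyl sulfur can matter more than the first steps showed. Yet a number 6 percentage points higher from compound 2 to compound 4 (within the scatter) so 3,4-dimethoxyphenyl and 2,5-dibromophenyl cannot be told apart here. Nothing available explains these steps. Open, on these data alone, is whether a single methoxy group on the phenyl ring would serve as well as two. Also open, as far as these compounds go, is whether a methyl group could replace the aryl ring altogether.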